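This account rests on a few compounds, and the source may have more. Where it says the series, first, only, none or still open, it means among the compounds named here.

Compound 1 `O=C1NCCN1c1ccc(S(=O)(=O)Nc2cccc(Br)c2)cc1`: 100 nM
Compound 2 `COc1ccc(NS(=O)(=O)c2ccc(N3CCNC3=O)cc2)cc1`: > 1000 nM
Compound 3 `CC(C)Cc1ccc(NS(=O)(=O)c2ccc(N3CCNC3=O)cc2)cc1`: > 1000 nM

In a functional assay on MCF7 cells (Homo sapiens) for antiproliferative activity, read by sulforhodamine B assay, with a stated time of 48 h (on this read-out lower numbers stand for stronger inhibition and higher numbers for weaker inhibition), compound 1 gives 100 nM. For compound 2 the reported > 1000 nM is a limit of the assay, not a number. For compound 3 the reported > 1000 nM is likewise a limit. On these data alone, compound 3 therefore stands at the limit of > 1000 nM in this assay, at which 2 of the 3 values shown sit, and its true value is unknown beyond that.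

Of the measured steps, an at least 10-fold higher number from compound 1 to compound 2 (1.00 log units; beyond the scatter). The step that the two limits leave unreadable from compound 2 to compound 3, since both ends are limits.

Compound 4 `O=C1NCCN1c1ccc(S(=O)(=O)Nc2ccc(F)cc2)cc1` differs from compound 3 by fluoro in place of isobutyl on an aromatic carbon. Among the measured compounds shown here, no measured step exchanges one group for another at this position with a readable outcome, so the change from compound 3 to compound 4 has no direct precedent. For the measured compounds named here, the only readable step is the move from compound 1 to compound 2, which concerns a different exchange. Compound 4 is therefore expected at 600 nM, with a range from 150 nM to 3000 nM. This amounts to an expected step of an at least 1.6-fold lower number from compound 3 to compound 4 (0.22 log units; that floor lies within the scatter), with a real chance that only a limit is reported.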

Compound 4, half-maximal inhibitory concentration: 690 nM
For compound 4 the middle estimate is 1.2-fold (0.06 log units) below the measured one; low and high end bracket the measured number.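

Among the compounds shown here, with fluoro on the aromatic carbon para to a large group, compound 4 is the first of the compounds with a group at this place to give a number rather than a limit in this assay. Fluoro in place of isobutyl gives an at least 1.4-fold lower number from compound 3 to compound 4 (0.16 log units; that floor lies within the scatter) and fluoro in place of methoxy gives an at least 1.4-fold lower number from compound 2 to compound 4 (0.16 log units; that floor lies within the scatter), and both are only floors because compound 2 and compound 3 each stand at a limit: the limit of > 1000 nM in this assay, at which 2 of the 4 values shown sit. The 4-fluorophenyl in place of 3-bromophenyl on the sulfonamide nitrogen gives a 6.9-fold higher number from compound 1 to compound 4 (0.84 log units; beyond the scatter), which, unlike the step to compound 2, has a readable size.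

Compound 1 and compound 4 differ in both the halogen and its place on the aromatic ring, and the compounds shown do not separate these two changes. On these data alone, it also stays open how a 4-bromophenyl, a 3-fluorophenyl or a chloro at the place of the fluoro would read.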